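The compounds below may be only part of what the source reports. "The series", "measured", "known", "first", "only" and "open" are said of these compounds alone.

Measured so far:
Compound 1, `CCN(CC)C/C=C/C(=O)Nc1cc2c(N3CCc4ccccc43)ncnc2cc1O[C@@H]1CCOC1`, 5780 nM
Compound 2, `CCN(CC)C/C=C/C(=O)Nc1cc2c(N3CCCc4ccccc43)ncnc2cc1OC`, 6890 nM

Compound 2 has the higher of the two numbers in a functional assay on PC-3 cells (Homo sapiens) for antiproliferative activity, read by MTT assay, with a stated time of 72 h (on this read-out lower numbers stand for stronger inhibition and higher numbers for weaker inhibition), but its nearest neighbour, compound 1, sits close enough that the two values fall within the ordinary scatter of repeated measurements, so neither can be called more or less active than the other. Compound 1 and compound 2 also differ in two places, not one, so their pair does not isolate any single change.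

Compound 3, `CCN(CC)C/C=C/C(=O)Nc1cc2c(N3CCCc4ccccc43)ncnc2cc1O[C@@H]1CCOC1`, keeps the whole of compound 2 and alters a single site: oxolan-3-yl in place of methyl on an oxygen on an aromatic ring. Within the data shown here, the same swap of methyl for oxolan-3-yl on that oxygen is the one present in compound 1, where it accompanies a different ring on the core, and the value of compound 1 lies alongside that of compound 2.

Among the measured compounds shown here, with no measured pair isolating this change, the expectation for compound 3 in this assay is a step of a 1.2-fold lower number from compound 2 to compound 3 (0.07 log units; within the scatter), that is, no movement beyond the scatter in either direction. Compound 3 is therefore estimated at 5800 nM, with a likely range from 2600 nM to 13000 nM.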

Compound 3, half-maximal inhibitory concentration: 4270 nM
Compound 3: the middle estimate sits 1.4-fold (0.13 log units) above what was measured; low and high end bracket the measured number.
By their numbers in this assay, from the lowest: compounds 3, 1 and 2 (each within the scatter of the next).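

In this assay, the swap of methyl for oxolan-3-yl on an oxygen on an aromatic ring can now be read on its own, and it gives no change that stands out from the scatter (a 1.6-fold lower number from compound 2 to compound 3 (0.21 log units; within the scatter)), so at this position a single carbon can give way to a group of five heavy atoms with a ring, a hydrogen-bond acceptor and a defined stereocentre without a clear change in the read-out. With the (oxolan-3-yl)oxy group held fixed, the change of ring on an aromatic carbon, 1,2,3,4-tetrahydroquinolin-1-yl in place of 2,3-dihydro-1H-indol-1-yl, also stays within the scatter (a 1.4-fold lower number from compound 1 to compound 3 (0.13 log units; within the scatter)), so neither single change separates these compounds in this assay. No further data accompany these numbers that could explain why both changes leave the read-out so flat.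

Still open, on these data alone, is whether a different kind of group on that oxygen, such as a longer chain ending in an amine like morpholine, would move the number beyond the scatter. The mirror-image form of the oxolan-3-yl group also remains an open question at this position.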